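Series notes: 4-hydroxy-3-methoxyphenyl in place of 4-bromophenyl

The compounds below may be only part of what the source reports. "The series", "measured", "known", "first", "only" and "open" are said of these compounds alone.

Among the compounds with values here, in a functional assay on MGC-803 cells (Homo sapiens) for cytotoxicity, read by MTT assay, with a stated time of 72 h (a higher number here means a weaker inhibitor, a lower number a stronger inhibitor), compound 1 `O=C1C(=Cc2ccc(F)cc2)C(=O)N(c2ccc(Cl)cc2)N1c1ccc(Cl)cc1` gives 26000 nM and compound 2 `O=C1C(=Cc2ccc(Br)cc2)C(=O)N(c2ccc(Cl)cc2)N1c1ccc(Cl)cc1` gives 16900 nM, so compound 2 stands within the scatter of its only measured neighbour. Compound 3 `COc1cc(C=C2C(=O)N(c3ccc(Cl)cc3)N(c3ccc(Cl)cc3)C2=O)ccc1O` differs from compound 2 on a double-bonded chain carbon bound to a double-bonded ring carbon: 4-hydroxy-3-methoxyphenyl in place of 4-bromophenyl on a double-bonded chain carbon bound to a double-bonded ring carbon. Within the data shown here, the only measured step, a 1.5-fold lower number from compound 1 to compound 2 (0.19 log units; within the scatter), is bromo in place of fluoro on an aromatic carbon and does not test the entering group. The estimated step is a 1.1-fold lower number from compound 2 to compound 3 (0.05 log units; within the scatter), so no change beyond the scatter is expected in this assay, in either direction. For compound 3 the estimated value is 15000 nM, with an expected range of 6000 nM to 35000 nM.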

Compound 3, half-maximal inhibitory concentration: 21800 nM
The estimate for compound 3 lay 1.5-fold (0.16 log units) below the measured number, and the stated range covers the measured number.
By their numbers in this assay, from the lowest: compounds 2, 3 and 1 (each within the scatter of the next).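

At this place, on a double-bonded chain carbon bound to a double-bonded ring carbon, the earlier pair compared only halogen-bearing rings. In this assay, 4-hydroxy-3-methoxyphenyl in place of 4-bromophenyl (a 1.3-fold higher number from compound 2 to compound 3 (0.11 log units; within the scatter)) and in place of 4-fluorophenyl (a 1.2-fold lower number from compound 1 to compound 3 (0.08 log units; within the scatter)) shows that a larger group with a hydrogen-bond donor and acceptors brings no step beyond the scatter. No evidence here bears on this result. Still open, as far as these compounds go, is whether an amine or a carboxylic acid on this ring, or a longer chain in its place, would move the number beyond the scatter.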